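The compounds below may be only part of what the source reports. "The series", "measured", "known", "first", "only" and "open" are said of these compounds alone.

Measured compounds:
compound 1 `Cc1cc2[nH]nc(N)c2c(=O)[nH]1`: 8%
compound 2 `Nc1n[nH]c2cc(-c3cccnc3)[nH]c(=O)c12`: 12%
compound 3 `Nc1n[nH]c2cc(-c3ccccn3)[nH]c(=O)c12`: 18%

Of the compounds shown here, three sharing one core have been tested in an assay on isolated protein for inhibition of MAP kinase-activated protein kinase 5 (Homo sapiens), read by mobility shift assay, tested at 30 uM; on this read-out higher numbers stand for more inhibition at the one concentration tested (going by the name of the read-out) and lower numbers for less inhibition. Compound 1 gives 8%, the smallest of the three numbers as written, yet compound 2 with 12% and compound 3 with 18% both sit within the usual scatter of it, so no real ordering among the three can be read from these figures. Compound 4 `Nc1n[nH]c2cc(-c3cccs3)[nH]c(=O)c12` has not yet been measured. It differs from compound 1 in one place: thiophen-2-yl in place of methyl on an aromatic carbon. Compounds 2 and 3 carry other aromatic rings in the same place and gave numbers close to that of compound 1, so the step from compound 1 to compound 4 is expected to be small, a slight rise at most: a number 6 percentage points higher from compound 1 to compound 4 (within the scatter). Compound 4 is therefore expected to give 14% in this assay, most likely between 4% and 28%.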

Compound 4, a percentage reported as inhibition, at one concentration (the size of the read-out at that concentration, not a potency): 12%
The estimate for compound 4 lay 2 percentage points above the measured number; measured number inside the range.
By their numbers in this assay, from the lowest: compounds 1, 2, 4 and 3 (each within the scatter of the next).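

Thiophen-2-yl in place of methyl on this aromatic carbon reads in this assay as a number 4 percentage points higher from compound 1 to compound 4 (within the scatter) and so cannot be told apart from methyl. A five-membered aromatic ring with sulfur thus joins the larger groups at this position that give no separable result, and none of them stands clear of compound 1. No available evidence bears on why this is so.

Going by these compounds, whether a carboxylic acid, an amine or a longer chain on this carbon would move the number beyond the scatter of compound 1 remains open. So does whether changes elsewhere on the shared core would do so.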